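Working notes: from 2,3,5-trimethoxyphenyl to 3,4,5-trimethoxyphenyl

The compounds below may be only part of what the source reports. "The series", "measured", "known", "first", "only" and "open" are said of these compounds alone.

Values measured in an ADME assay on cells (Lymphocyte, Homo sapiens) for cytotoxicity, read by MTT assay, with a stated time of 48 h (on this read-out lower numbers stand for stronger inhibition and higher numbers for weaker inhibition), are as follows
Compound 1 `COC(=O)/C(=C\c1ccc(OC(=O)c2ccccc2OC)cc1)Sc1ccnc2cc(Cl)ccc12` gives > 100000 nM as a limit
Compound 2 `COC(=O)/C(=C\c1ccc(OC(=O)c2c(OC)cccc2OC)cc1)Sc1ccnc2cc(Cl)ccc12` gives > 100000 nM as a limit
Compound 3 `COC(=O)/C(=C\c1ccc(OC(=O)c2cc(OC)cc(OC)c2OC)cc1)Sc1ccnc2cc(Cl)ccc12` gives 74000 nM as a number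

For the measured compounds named here, compound 3 holds the only actual number here, and the other evidence is the limit of > 100000 nM in this assay, at which 2 of the 3 values shown sit, alone. Compound 4 `COC(=O)/C(=C\c1ccc(OC(=O)c2cc(OC)c(OC)c(OC)c2)cc1)Sc1ccnc2cc(Cl)ccc12` differs from it by 3,4,5-trimethoxyphenyl in place of 2,3,5-trimethoxyphenyl on a carbonyl carbon with 3,4,5-trimethoxyphenyl in place of 2,3,5-trimethoxyphenyl on a carbonyl carbon, the same atoms joined differently. Bearing on this are an at least 1.3-fold lower number from compound 1 to compound 3 (0.13 log units; that floor lies within the scatter) and an at least 1.3-fold lower number from compound 2 to compound 3 (0.13 log units; that floor lies within the scatter) as floors within the scatter, while a step that the two limits leave unreadable from compound 1 to compound 2 stays unreadable. These give no direction, so no change beyond the scatter is expected in this assay here. The expected step is a 1.1-fold higher number from compound 3 to compound 4 (0.06 log units; within the scatter) and stays within the scatter. For compound 4 the estimate is 85000 nM with an expected range from 40000 nM to 170000 nM in this series.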

Compound 4, half-maximal inhibitory concentration: 35200 nM
Compound 4: middle estimate off by 2.4-fold (0.38 log units), on the high side, and the stated range ends above it.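

In this assay the same atoms joined as 3,4,5-trimethoxyphenyl rather than 2,3,5-trimethoxyphenyl on this carbonyl carbon give a 2.1-fold lower number from compound 3 to compound 4 (0.32 log units; beyond the scatter) and so the arrangement alone moves the value beyond the scatter. Compound 3 gave only floors within the scatter against the two limit compounds, whereas the new group gives an at least 2.8-fold lower number from compound 2 to compound 4 (0.45 log units; beyond the scatter) and an at least 2.8-fold lower number from compound 1 to compound 4 (0.45 log units; beyond the scatter) as floors beyond it. Both stay floors and not sizes because compounds 1 and 2 rest on a limit: the limit of > 100000 nM in this assay, at which 2 of the 4 values shown sit.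

Left open is how an amine or a carboxylic acid in place of the 3,4,5-trimethoxyphenyl group would read in this assay on this carbonyl carbon.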